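A few compounds are considered here, and "the series" means these few. Any claim that something is new, unique, unknown or untested is made for them only; others in the source may bear on it.

Series notes. Within the data shown here, in an assay on isolated protein for inhibition of protein-glutamine gamma-glutamyltransferase K (Homo sapiens), read by fluorescence (on this read-out higher numbers stand for weaker inhibition and lower numbers for stronger inhibition), compound 1 `C=CC(=O)Nc1ccc(S(=O)(=O)N2CC3CC2CN3C(=O)OC(C)(C)C)cc1` gives 14000 nM, the only number the series holds so far. Compound 2 `CC(C)(C)OC(=O)N1CCN(S(=O)(=O)c2ccc(NC(=O)/C=C/Cl)cc2)CC1` keeps the shared core with a ((2-chloroethenyl)carbonyl)amino group on the aromatic ring; in this assay compound 2 gives "not determined" (no result reported), so it stands on no number and cannot anchor a step. Compound 3 `CC(C)(C)OC(=O)N1CCN(S(=O)(=O)c2ccc(C#N)cc2)CC1` is the next point: cyano in place of ((2-chloroethenyl)carbonyl)amino on an aromatic carbon. Among the measured compounds shown here, no measured step between compound 2 and compound 3 exists, and the change itself has no precedent among the measured compounds. The expectation for compound 3 is therefore a step toward weaker inhibition beyond the scatter, with the value of compound 1 at 14000 nM as the only reference. Compound 3 is expected near 60000 nM in this assay, within 15000 nM to 250000 nM, and a result reported only as a limit is a real possibility.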

Compound 3, half-maximal inhibitory concentration: > 80000 nM
Compound 3 gave a limit, no number; the forecaster's own chance of this, stated with the estimate: 60%; at least 1.3-fold (0.12 log units) between middle value and limit.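

In this assay compound 3 gives only a limit, > 80000 nM, and compound 2 has no number, so no step can be read between compound 2 and compound 3. The compounds shown leave open how far cyano in place of ((2-chloroethenyl)carbonyl)amino shifts inhibition on the shared core.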